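Sulfonyl quinoxaline anilines: chloro to trifluoromethyl in cytotoxicity

The compounds below may be only part of what the source reports. "The series", "measured", "known", "first", "only" and "open" are said of these compounds alone.

This account concerns four compounds built on a shared quinoxaline-type core bearing an arylsulfonyl group and an anilino group, tested in a functional assay on A549 cells (Homo sapiens) for cytotoxicity, read by MTT assay, with a stated time of 72 h; on this read-out higher numbers stand for weaker inhibition and lower numbers for stronger inhibition. Compound 1 `O=S(=O)(c1ccccc1)c1nc2ccccc2nc1Nc1ccc(Cl)cc1` gives 30700 nM in this assay. Compound 2 `O=S(=O)(c1ccccc1)c1nc2ccccc2nc1Nc1ccc(C(F)(F)F)cc1` differs from compound 1 by trifluoromethyl in place of chloro on an aromatic carbon. In this assay compound 2 reaches only the limit of > 50000 nM, a limit rather than a number, so the step of an at least 1.6-fold higher number from compound 1 to compound 2 (0.21 log units; that floor lies within the scatter) rests on (the limit of > 50000 nM in this assay, at which 1 of the 3 values shown sits). Compound 3 `O=S(=O)(c1ccc(Br)cc1)c1nc2ccccc2nc1Nc1ccc(Cl)cc1` differs from compound 1 by bromo in place of hydrogen on an aromatic carbon, and in this assay compound 3 gives 61400 nM, a step of a 2.0-fold higher number from compound 1 to compound 3 (0.30 log units; within the scatter). Compound 4 `O=S(=O)(c1ccc(Br)cc1)c1nc2ccccc2nc1Nc1ccc(C(F)(F)F)cc1`, not yet measured, stands to compound 3 as compound 2 stands to compound 1: trifluoromethyl in place of chloro on an aromatic carbon, the same change at the same kind of place. Given the step of an at least 1.6-fold higher number from compound 1 to compound 2 (0.21 log units; that floor lies within the scatter), compound 4 is expected to show a step of a 2.0-fold higher number from compound 3 to compound 4 (0.29 log units; within the scatter) from compound 3, and it is expected most likely to reach the assay limit rather than a number. The estimate for compound 4 is 120000 nM, expected to lie between 60000 nM and 300000 nM.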

Compound 4, half-maximal inhibitory concentration: > 50000 nM
Compound 4 ended at the assay's limit; the forecaster's own chance of this, stated with the estimate: 80%; the middle value lies beyond the limit too.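

In this assay compound 4 gives > 50000 nM, a limit of the assay and not a number. Neither the step from compound 3 to compound 4 nor the step from compound 2 to compound 4 can be read: the limit of > 50000 nM in this assay, at which 2 of the 4 values shown sit.

The compounds shown leave open whether trifluoromethyl in place of chloro has the same effect with and without the bromo.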